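This account rests on a few compounds, and the source may have more. Where it says the series, first, only, none or still open, it means among the compounds named here.

Measured so far:
- compound 1, `CCCS(=O)(=O)Nc1ccc(F)c(C(=O)c2n[nH]c3ncc(-c4ccccc4)cc23)c1F`: 2.4%
- compound 2, `CCCS(=O)(=O)Nc1ccc(F)c(C(=O)c2n[nH]c3ncc(-c4ccccc4N)cc23)c1F`: 23%

Both compounds were tested in an assay for binding affinity to dual specificity mitogen-activated protein kinase kinase 4 (Homo sapiens), read by KINOMEscan, tested at 100 nM; a higher number here means a weaker effect of the compound at the concentration tested, a lower number a stronger effect. Compound 1 gives 2.4% there, whereas compound 2 gives 23%, the higher of the two numbers. Among the compounds with values here, the only measured step, a number 20.6 percentage points higher from compound 1 to compound 2 (beyond the scatter), lies beyond the scatter. Compound 3, `CCCS(=O)(=O)Nc1ccc(F)c(C(=O)c2n[nH]c3ncc(-c4cccc(N(C)C)c4)cc23)c1F`, is not yet measured. It differs from compound 2 by 3-(dimethylamino)phenyl in place of 2-aminophenyl on an aromatic carbon. Within the data shown here, the single step that bears on this change is the one from compound 1 to compound 2, where an amino group was added; compound 3 again carries one nitrogen on the phenyl, but as 3-(dimethylamino)phenyl instead of 2-aminophenyl, so the earlier step is only a loose guide. A number close to that of compound 2 is expected, with wide uncertainty in either direction, giving an estimated a number 3 percentage points lower from compound 2 to compound 3 (within the scatter). The value of compound 3 is estimated at 20%, within a range from 4% to 55%.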

Compound 3, a percentage reported as activity, at one concentration (the size of the read-out at that concentration, not a potency): 26%
Compound 3: middle estimate off by 6 percentage points, on the low side, within the range that was stated.
By their numbers in this assay, from the lowest: compound 1; then compounds 2 and 3 (each within the scatter of the next).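

In this assay, replacing 2-aminophenyl with 3-(dimethylamino)phenyl gives a number 3 percentage points higher from compound 2 to compound 3 (within the scatter) in the read-out, so these two groups cannot be told apart here, even though the nitrogen sits at a different place on the phenyl ring and carries two methyl groups instead of hydrogens. Set against the plain phenyl, the dimethylamino group gives a number 23.6 percentage points higher from compound 1 to compound 3 (beyond the scatter) and so a weaker effect, which means that in these three compounds both nitrogen-bearing phenyl groups fall short of compound 1 by a similar margin. No measurement available here explains that loss.

Still open, as far as these compounds go, is whether the nitrogen matters at all, or whether a hydroxyl or methyl group on the phenyl ring would read the same. A 3-aminophenyl group would separate the effect of ring position from that of the two methyl groups.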